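Swapping a ring in a chalcone series against nasopharyngeal cells

A few compounds are considered here, and "the series" means these few. Any claim that something is new, unique, unknown or untested is made for them only; others in the source may bear on it.

Of the compounds shown here, three have been measured in a functional assay on CNE-2 cells (Homo sapiens) for antiproliferative activity, read by sulforhodamine B assay, with a stated time of 48 h; a lower number here means a stronger inhibitor, a higher number a weaker inhibitor.
Compound 1, `COc1ccc(C(=O)/C=C/c2ccccc2-c2ccc(F)cc2)cc1OC`, gives 7600 nM.
Compound 2, `COc1ccc(C(=O)/C=C/c2ccccc2-c2ccc(F)nc2)cc1OC`, gives 17000 nM.
Compound 3, `O=C(/C=C/c1ccccc1-c1ccc(F)cc1)c1cccc(O)c1`, gives 7300 nM.

Compound 1 and compound 2 share a core and differ in one place: 6-fluoropyridin-3-yl in place of 4-fluorophenyl on an aromatic carbon. That change gave a 2.2-fold higher number from compound 1 to compound 2 (0.35 log units; beyond the scatter). Compound 3 carries a different core; how it differs from the core of compound 1 is not broken down here, and the two values lie within the usual scatter of each other, so nothing can be said about their order.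

Compound 4, `O=C(/C=C/c1ccccc1-c1ccc(F)nc1)c1cccc(O)c1`, is not yet measured. It stands to compound 3 as compound 2 stands to compound 1: 6-fluoropyridin-3-yl in place of 4-fluorophenyl on an aromatic carbon. The place is described in the same words for both pairs, so this is the same change seen once before. Among the measured compounds shown here, with only that single prior step to rest on, the expected step is a 2.2-fold higher number from compound 3 to compound 4 (0.34 log units; beyond the scatter), set beside a 2.2-fold higher number from compound 1 to compound 2 (0.35 log units; beyond the scatter). Compound 4 is therefore estimated at 16000 nM, within a range from 8000 nM to 35000 nM.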

Compound 4, half-maximal inhibitory concentration: 8700 nM
For compound 4 the middle estimate is 1.8-fold (0.26 log units) above the measured one, and the stated range covers the measured number.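

On the second core, putting 6-fluoropyridin-3-yl in place of 4-fluorophenyl gave a 1.2-fold higher number from compound 3 to compound 4 (0.08 log units; within the scatter) in this assay, a step too small to tell apart from the ordinary spread of repeated measurements. Set beside the same swap on the first core, the two steps cannot be told apart: the same change on two cores in this assay, a 2.2-fold higher number (0.35 log units; beyond the scatter) from compound 1 to compound 2 and a 1.2-fold higher number (0.08 log units; within the scatter) from compound 3 to compound 4, 1.9-fold (0.27 log units) apart, within the scatter of two such steps

So these two pairs give no sign that the core alters what this swap does, but they do not prove that the step is the same on both, and they say nothing about any other core.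

The compounds shown leave open what would happen if the fluorine on either ring gave way to another group, such as an amine or a carboxylic acid. From the compounds shown here alone, it also remains open whether the swap would behave the same way on cell lines other than this one.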